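The compounds below may be only part of what the source reports. "The series", "measured", "known", "first", "only" and "open" are said of these compounds alone.

Of the compounds shown here, two of this acylphenol ether series have numbers so far. Compound 1 `Cc1c(OCCCCOc2ccccc2C(=O)O)ccc(C(=O)CC2CCCC2)c1O` is measured in an assay on HEK293 cells for positive allosteric modulation of metabotropic glutamate receptor 2 (Rattus norvegicus), read by thallium flux, with a stated time of 2.5 min (a lower number here means that less compound is needed, a higher number that more compound is needed for the effect), and gives 335 nM. Compound 2 `CCCC(=O)c1ccc(OCCCCOc2cc(C(=O)O)ccc2OC)c(C)c1O` in this assay gives 103 nM, the lowest of the two values; its nearest neighbour on the numbers is compound 1, whose value lies beyond the usual scatter of this measurement, so compound 2 does stand apart on potency among the two. Among the compounds with values here, the two compounds differ in more than one place, so no single structural step between them is available, and their values are taken only as what they are.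

Compound 3 `COc1ccc(C(=O)O)cc1OCCCCOc1ccc(C(C)=O)c(O)c1C` has not been measured. Relative to compound 2 the change is hydrogen in place of ethyl on a saturated chain carbon bound to a carbonyl carbon, read one bond further out as propylcarbonyl going to acetyl. Within the data shown here, no measured pair isolates this change, so the direction rests on the new compound alone. A step toward a higher number, beyond the scatter, is expected: a 3.9-fold higher number from compound 2 to compound 3 (0.59 log units; beyond the scatter). For compound 3 in this assay the estimate is 400 nM, with a plausible range from 150 nM to 1500 nM.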

Compound 3, half-maximal effective concentration: 1090 nM
The estimate for compound 3 lay 2.7-fold (0.44 log units) below the measured number; low and high end bracket the measured number.
By their numbers in this assay, from the lowest: compound 2; then compound 1; then compound 3.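

In this assay, within the data shown here, shortening propylcarbonyl to acetyl gives an 11-fold higher number from compound 2 to compound 3 (1.02 log units; beyond the scatter), and this is the first step that changes one place only: hydrogen in place of ethyl on a saturated chain carbon bound to a carbonyl carbon. With the rest of compound 2 unchanged, the loss of the ethyl alone moves the number well beyond the scatter, so this position is sensitive to this change on this background. No measured data bear on the reason for the step.

Among these compounds, two compounds give only one step at this position, so it remains open whether ethylcarbonyl would fall between them and whether a longer chain such as pentylcarbonyl would bring the number lower still or raise it again. On these data alone, compound 1 differs from compound 2 in more than one place, so it remains open whether the same change would have a step of similar size on the core of compound 1.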